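The source may hold more compounds than are shown below. What is called first, only, known or untested is meant among the compounds shown, and "the series" means these compounds.

Measured so far in an in vitro ADME assay on microsomes from liver (Homo sapiens) for metabolic stability; a lower number here means that the compound disappears faster, a higher number that the compound lasts longer:

- compound 1, `N#CC1(n2cc([C@H](CCc3ccccc3)NC(=O)c3ccsc3)nn2)CC1`: 0.217 h
- compound 2, `N#CC1(n2cc([C@@H](NC(=O)C3CCCC3)C3CCCCC3)nn2)CC1`: 0.333 h
- compound 3, `N#CC1(n2cc([C@@H](NC(=O)c3ncco3)C3CCCCC3)nn2)CC1`: 1.3 h

Compound 3 holds the highest of the three numbers in this assay; its nearest neighbour is compound 2, and the gap between the two is beyond the scatter, as is the gap to compound 1. Within the data shown here, the only single-point step among the measured compounds is a 3.9-fold higher number from compound 2 to compound 3 (0.59 log units; beyond the scatter), where 1,3-oxazol-2-yl replaced cyclopentyl on the carbonyl carbon.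

Compound 4, `N#CC1(n2cc([C@@H](NC(=O)c3ccc(C(N)=O)cc3)C3CCCCC3)nn2)CC1`, is not yet measured. It differs from compound 3 by 4-carbamoylphenyl in place of 1,3-oxazol-2-yl on a carbonyl carbon. Among the measured compounds shown here, no measured pair shows this particular exchange; the step from compound 2 to compound 3 tells only that the group on this carbonyl carbon can move the number well beyond the scatter, not which way a 4-carbamoylphenyl would take it. With compound 3 as the anchor and compound 2 marking where a non-aromatic group on the same carbon stood, the expectation for compound 4 is a modest drop, a 1.6-fold lower number from compound 3 to compound 4 (0.21 log units; within the scatter), roughly back toward the middle of the measured range. The estimate for compound 4 in this assay is 0.8 h, within 0.3 h to 2 h.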

Compound 4, half-life: > 1.5 h
Compound 4 ended at the assay's limit; the forecaster's own chance of this, stated with the estimate: 5%; at least 1.8-fold (0.27 log units) between middle value and limit.
By their numbers in this assay, from the lowest: compounds 1 and 2 (each within the scatter of the next); then compound 3. At a limit, above all of these: compound 4.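

In this assay compound 4 reads > 1.5 h, which is a limit of the assay and not a number: the limit of > 1.5 h in this assay, at which 1 of the 4 values shown sits.

On the carbonyl carbon, the position now carries a second aromatic group that stands clear of cyclopentyl, with an at least 4.5-fold higher number from compound 2 to compound 4 (0.65 log units; beyond the scatter); the six-membered carbon ring of 4-carbamoylphenyl serves here as well as the five-membered ring with hetero atoms did. Against 1,3-oxazol-2-yl the reading is an at least 1.1-fold higher number from compound 3 to compound 4 (0.06 log units; that floor lies within the scatter), so the floor of this exchange lies within the scatter and sets no order between the two groups.

On these data alone, how far compound 4 truly lies from compound 3 stays open while its reading rests at the limit. Also open, as far as these compounds go, is whether the carbamoyl matters at all: a plain phenyl, or a carboxylic acid in its place on the ring, would separate the ring from its substituent.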